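This account rests on a few compounds, and the source may have more. Where it says the series, first, only, none or still open, it means among the compounds named here.

Measured so far in a physicochemical assay for solubility, read by HPLC, with a stated time of 20 h, at pH 1; on this read-out lower numbers stand for lower solubility and higher numbers for higher solubility:
compound 1 `O=C(Nc1nc(Cc2ccccc2)no1)c1ccc(O[C@H]2CC[C@@H](C(=O)O)CC2)cc1`: < 2000 nM
compound 2 `NC(=O)C[C@H]1CC[C@H](c2ccc(C(=O)Nc3nnc(Cc4ccccc4)s3)cc2)CC1`: < 2000 nM
compound 3 `CC(C)(O)CNC(=O)C[C@H]1CC[C@H](c2ccc(C(=O)Nc3nnc(Cc4ccccc4)s3)cc2)CC1`: < 2000 nM

None of these entries is a number: the series sits at the limit of < 2000 nM in this assay, at which 3 of the 3 values shown sit. Compound 3 carries only the limit < 2000 nM, so its place among the others cannot be ranked.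

Compound 4 `O=C(C[C@H]1CC[C@H](c2ccc(C(=O)Nc3nnc(Cc4ccccc4)s3)cc2)CC1)NCC(O)CO` has not yet been measured. The structural change is 1,2-dihydroxyethyl in place of 1-hydroxy-1-methylethyl on a saturated chain carbon bound to an amide-type nitrogen. In words, 1,2-dihydroxyethyl stands in place of 1-hydroxy-1-methylethyl on a saturated chain carbon bound to an amide-type nitrogen.

Among the measured compounds shown here, the one measured step that bears on this change is a step that the two limits leave unreadable from compound 2 to compound 3. It concerns the same amide-type nitrogen, but it offers no size to carry over. For the measured compounds named here, with that step as the only guide, no change beyond the usual scatter is expected in this assay, and no direction can be given.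

The expected step is a step that the limit leaves unreadable from compound 3 to compound 4. For compound 4 the estimated value is 1500 nM, with an expected range from 400 nM to 5000 nM.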

Compound 4, solubility: < 2000 nM
Compound 4 ended at the assay's limit; the forecaster's own chance of this, stated with the estimate: 75%; the middle value lies beyond the limit too.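

In this assay compound 4 gives < 2000 nM, which is a limit and not a number. No step among compound 2, compound 3 and compound 4 can be read: the limit of < 2000 nM in this assay, at which 4 of the 4 values shown sit.

The compounds shown leave open whether 2,3-dihydroxypropyl and 2-hydroxy-2-methylpropyl differ at all in this assay.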